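Naphthalenyl Amide Tested Against a Phosphatase Assay Limit

This account rests on a few compounds, and the source may have more. Where it says the series, first, only, none or still open, it means among the compounds named here.

Measured so far:
Compound 1 `O=C(COc1ccc2cc(C(O)(C(F)(F)F)C(F)(F)F)c(O)cc2c1)Nc1nc2ccccc2s1` gives 10900 nM.
Compound 2 `O=C(COc1ccc2cc(C(O)(C(F)(F)F)C(F)(F)F)c(O)cc2c1)NCc1ccc(F)cc1` reaches only a limit of the assay, > 20000 nM.
Compound 3 `O=C(COc1ccc2cc(C(O)(C(F)(F)F)C(F)(F)F)c(O)cc2c1)Nc1ccccc1` reaches only a limit of the assay, > 20000 nM.

Going by the values given here, in an assay on isolated protein for inhibition of receptor-type tyrosine-protein phosphatase C (Homo sapiens), read by spectrophotometry (on this read-out higher numbers stand for weaker inhibition and lower numbers for stronger inhibition), compound 1 is the one compound with a number of its own. Compound 3 stands at the limit of > 20000 nM in this assay, at which 2 of the 3 values shown sit, so its true inhibition is known only as weaker than that limit. Compound 4 `O=C(COc1ccc2cc(C(O)(C(F)(F)F)C(F)(F)F)c(O)cc2c1)Nc1cccc2ccccc12` differs from compound 3 by naphthalen-1-yl in place of phenyl on an amide-type nitrogen. Among the compounds with values here, no measured step swaps phenyl for naphthalen-1-yl, so the nearest guides are an at least 1.8-fold higher number from compound 1 to compound 3 (0.26 log units; that floor lies within the scatter) and an at least 1.8-fold higher number from compound 1 to compound 2 (0.26 log units; that floor lies within the scatter), both of which run from a compound bearing a group with two fused rings on the amide nitrogen up to the limit. Compound 4 carries two fused aromatic rings again, which suggests it could return to a readable number, though the floors of those steps lie within the scatter. A modest lowering is therefore expected, an at least 1.3-fold lower number from compound 3 to compound 4 (0.12 log units; that floor lies within the scatter), with a real chance of another limit. Compound 4 is estimated at 15000 nM, with a range from 5000 nM to 40000 nM.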

Compound 4, half-maximal inhibitory concentration: 29100 nM
For compound 4 the middle estimate is 1.9-fold (0.29 log units) below the measured one, and the stated range covers the measured number.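

In this assay compound 4 has a number of its own, 29100 nM, so naphthalen-1-yl on the amide nitrogen gives a readable result, yet one that offers no sign of stronger inhibition than the phenyl of compound 3. Two fused rings on this nitrogen are not enough by themselves to match compound 1, as the change from 1,3-benzothiazol-2-yl to naphthalen-1-yl gives a 2.7-fold higher number from compound 1 to compound 4 (0.43 log units; beyond the scatter). The steps to compound 4 from compound 2 and compound 3 cannot be read, as both of those compounds sit at a limit: the limit of > 20000 nM in this assay, at which 2 of the 4 values shown sit.

On these data alone, it remains open whether the advantage of compound 1 depends on the nitrogen and sulfur in its ring system or on how that ring system is attached. A 1,3-benzoxazol-2-yl or a single thiazol-2-yl group on the same nitrogen would help to separate these possibilities.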